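Swapping the aryl group on the sulfonamide of a thioacetate series

This account rests on a few compounds, and the source may have more. Where it says the series, first, only, none or still open, it means among the compounds named here.

Measured compounds:
Compound 1, `CC(=O)SCC(=O)c1ccc(NS(=O)(=O)c2ccc(Cl)cc2)cc1`: 30800 nM
Compound 2, `CC(=O)SCC(=O)c1ccc(NS(=O)(=O)c2ccc(Cl)c(Cl)c2)cc1`: "not determined" (no result reported)
Compound 3, `CC(=O)SCC(=O)c1ccc(NS(=O)(=O)c2cccc(F)c2)cc1`: "not determined" (no result reported)

These three compounds share one core and differ only in the aryl group attached to the sulfonyl sulfur. In a functional assay on HCT-116 cells (Homo sapiens) for cytotoxicity (on this read-out lower numbers stand for an effect already at smaller amounts and higher numbers for an effect only at larger amounts of compound), compound 1 gives 30800 nM, an effect reached only at large amounts of compound. In this assay compound 2 gives "not determined" (no result reported), and compound 3 gives "not determined" (no result reported), so compound 3 stands without a measured position; the only anchor for the series is compound 1. No comparison between two measured compounds can be drawn from these data.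

Compound 4, `CC(=O)SCC(=O)c1ccc(NS(=O)(=O)c2ccc(C)cc2)cc1`, has not been measured. It differs from compound 3 as follows: 4-methylphenyl in place of 3-fluorophenyl on a sulfonyl sulfur. Since compound 3 carries no value, the expectation for compound 4 rests on compound 1 alone, whose 4-chlorophenyl group is replaced by a 4-methylphenyl group of the same size. No step beyond the scatter in this assay is expected in either direction. Compound 4 is therefore estimated to give 30000 nM in this assay, within a range of 8000 nM to 120000 nM.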

Compound 4, half-maximal effective concentration: 6500 nM
Compound 4: the middle estimate sits 4.6-fold (0.66 log units) above what was measured; the measured number lies below the stated range.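

Among the compounds shown here, until now the series had only one number, so nothing showed whether the aryl group on the sulfonyl sulfur affects the read-out at all. In this assay the change from chloro to methyl on an aromatic carbon brings a 4.7-fold lower number from compound 1 to compound 4 (0.68 log units; beyond the scatter) and so gives the first sign that this part of the molecule matters, even though the change is a single small group. No measurement shown here accounts for this step.

For the compounds shown here, neither compound 2 nor compound 3 has a number, so no step involving either of them can be read. Going by these compounds alone, with only one readable step there is no trend yet, and it remains open how the read-out would respond if a methoxy group, an amine or a carboxylic acid sat on that same aromatic carbon.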